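Moving the methyl on the aryl of compound 3

This account rests on a few compounds, and the source may have more. Where it says the series, first, only, none or still open, it means among the compounds named here.

Three measured compounds share one core and differ only in the aryl group on the amide-type nitrogen in a ring. Compound 1 `O=C1CC(c2nc(-c3cccc(Cl)c3)no2)CN1c1ccc(Cl)cc1` carries a 4-chlorophenyl there; in an in vitro functional assay on HEK293-A cells for negative allosteric modulation of metabotropic glutamate receptor 5 (Homo sapiens), read by FLIPR and calcium flux (a lower number here means a stronger inhibitor, a higher number a weaker inhibitor), compound 1 gives > 10000 nM, which is a limit of the assay rather than a number. Compound 2 `O=C1CC(c2nc(-c3cccc(Cl)c3)no2)CN1c1ccc(Cl)c(Cl)c1` carries a 3,4-dichlorophenyl; in this assay compound 2 gives > 10000 nM, again a limit. Among the compounds with values here, compound 3 `Cc1cccc(N2CC(c3nc(-c4cccc(Cl)c4)no3)CC2=O)c1` carries a 3-methylphenyl, and in this assay compound 3 gives 2300 nM, the only number among the three. Compound 1 and compound 2 sit at the assay limit (the limit of > 10000 nM in this assay, at which 2 of the 3 values shown sit). The step of an at least 4.3-fold lower number from compound 1 to compound 3 (0.63 log units; beyond the scatter) and the step of an at least 4.3-fold lower number from compound 2 to compound 3 (0.63 log units; beyond the scatter) both favour compound 3, while the step that the two limits leave unreadable from compound 1 to compound 2 cannot be read.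

Compound 4 `Cc1ccc(N2CC(c3nc(-c4cccc(Cl)c4)no3)CC2=O)cc1` has not yet been measured. It differs from compound 3 in one place: 4-methylphenyl in place of 3-methylphenyl on an amide-type nitrogen in a ring. Within the data shown here, no measured step moves a methyl on this aryl, so the change is untested. Among the measured compounds shown here, the one compound whose aryl carries its substituent as a 4-chlorophenyl, compound 1, sits at the limit, which gives some weight to a weaker compound 4. Compound 4 is therefore expected to show a modest step upward, a 2.2-fold higher number from compound 3 to compound 4 (0.34 log units; beyond the scatter). The estimate for compound 4 in this assay is 5000 nM, with a range from 1800 nM to 15000 nM.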

Compound 4, half-maximal inhibitory concentration: > 10000 nM
Compound 4 was reported as a limit (the forecaster's own chance of this, stated with the estimate: 35%); middle value at least 2.0-fold (0.30 log units) from the limit.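

In this assay, putting 4-methylphenyl in place of 3-methylphenyl on the amide-type nitrogen gives an at least 4.3-fold higher number from compound 3 to compound 4 (0.63 log units; beyond the scatter), so at this place the result depends on where the methyl stands on the aryl, even though the atoms are the same. Compound 4 gives > 10000 nM, which is a limit and not a number. The 4-chlorophenyl of compound 1, the 3,4-dichlorophenyl of compound 2 and the 4-methylphenyl of compound 4 now stand at one limit, and the 3-methylphenyl of compound 3 alone gives a number, a pattern that holds only for these four compounds and against which none of them goes: the limit of > 10000 nM in this assay, at which 3 of the 4 values shown sit.

The steps to compound 4 from compound 1 and from compound 2 join two limits and cannot be read, so the chloro and methyl groups cannot be ranked against each other at this place. From the compounds shown here alone, it stays open whether a 3-chlorophenyl, a 3-methoxyphenyl or an unsubstituted phenyl on that nitrogen would match or improve on compound 3 in this assay.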